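The compounds below may be only part of what the source reports. "The series", "measured", "known", "first", "only" and "open" are said of these compounds alone.

Measured compounds:
Compound 1 `COc1ccc(C2C(C#N)=C(N)N(c3cc(OC)c(OC)c(OC)c3)C3=C2C(=O)CC(C)(C)C3)cc1`, in a functional assay on Ehrlich cells (Mus musculus) for cytotoxicity, tested at 25 ug/mL (a higher number here means a stronger effect of the compound at the concentration tested, a lower number a weaker effect), giving 1%.
Compound 2 `COc1cc(N2C(N)=C(C#N)C(/C=C/c3ccccc3)C3=C2CC(C)(C)CC3=O)cc(OC)c1OC`, in this assay giving 30%.
Compound 3 `COc1cc(N2C(N)=C(C#N)C(c3ccc(OC)c4ccccc34)C3=C2CC(C)(C)CC3=O)cc(OC)c1OC`, in this assay giving 30%.

Compound 3 stands level with compound 2 at the digits reported, and together they give the two highest of the three numbers; the gap no change at the digits printed from compound 2 to compound 3 (within the scatter) lies within the scatter, whereas a number 29 percentage points higher from compound 1 to compound 3 (beyond the scatter) lies beyond it.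

Compound 4 `COc1ccccc1C1C(C#N)=C(N)N(c2cc(OC)c(OC)c(OC)c2)C2=C1C(=O)CC(C)(C)C2` has not yet been measured. Its change from compound 3 is 2-methoxyphenyl in place of 4-methoxynaphthalen-1-yl on a saturated ring carbon.

Among the compounds with values here, only one measured step bears on this change, in reverse: a number 29 percentage points higher from compound 1 to compound 3 (beyond the scatter), a modest rise when 4-methoxynaphthalen-1-yl replaced 4-methoxyphenyl. Going back from 4-methoxynaphthalen-1-yl to a methoxyphenyl is therefore expected to undo much of that gain, though the entering 2-methoxyphenyl is not the same group as the 4-methoxyphenyl of compound 1, so the size is uncertain. The step is expected to be a number 22 percentage points lower from compound 3 to compound 4 (beyond the scatter), downward and beyond the scatter. Compound 4 is estimated to give 8%, in the range 0% to 30%.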

Compound 4, a percentage reported as activity, at one concentration (the size of the read-out at that concentration, not a potency): 65%
Compound 4: the middle estimate sits 57 percentage points below what was measured; measured number above the stated range.
By their numbers in this assay, from the lowest: compound 1; then compounds 2 and 3 (each within the scatter of the next); then compound 4.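

In this assay, within the data shown here, the largest step so far comes from moving between two methoxyphenyl groups on the saturated ring carbon: a number 64 percentage points higher from compound 1 to compound 4 (beyond the scatter) when 2-methoxyphenyl replaces 4-methoxyphenyl, so where the methoxy group stands on the phenyl ring matters greatly here. Among these compounds, the 2-methoxyphenyl group also exceeds the other two groups, with a number 35 percentage points higher from compound 3 to compound 4 (beyond the scatter) against 4-methoxynaphthalen-1-yl and a number 35 percentage points higher from compound 2 to compound 4 (beyond the scatter) against 2-phenylethenyl, whereas the only methoxyphenyl among the earlier compounds had given the lowest number. No measured evidence shown here accounts for this rise.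

From the compounds shown here alone, whether a 2-hydroxyphenyl, 2-chlorophenyl or plain phenyl group on this carbon would hold the high number remains open, and so does the role of the methoxy group itself. A read-out at one concentration also leaves the potency of compound 4 unsettled.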